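Working notes: from the fluoro ester to the hydroxy

A few compounds are considered here, and "the series" means these few. Any claim that something is new, unique, unknown or untested is made for them only; others in the source may bear on it.

In a functional assay on A549 cells (Homo sapiens) for antiproliferative activity, read by MTT assay, with a stated time of 6 days (a higher number here means a weaker inhibitor, a lower number a stronger inhibitor), compound 1 `O=C1C=C[C@@H](OCc2ccccc2)[C@@H]([C@@H](COC(=O)/C=C/c2ccccc2)OCc2ccccc2)O1` gives 13300 nM in the series, compound 2 `O=C1C=C[C@@H](OCc2ccccc2)[C@@H]([C@@H](COC(=O)/C=C/c2ccc(F)cc2)OCc2ccccc2)O1` gives 12100 nM and compound 3 `O=C1C=C[C@@H](OCc2ccccc2)[C@@H]([C@@H](COC(=O)/C=C/c2ccc([N+](=O)[O-])cc2)OCc2ccccc2)O1` gives 5240 nM on the same shared core. Compound 2 holds the second highest of these three numbers. On one side stands a 1.1-fold lower number from compound 1 to compound 2 (0.04 log units; within the scatter) and on the other 2.3-fold lower number from compound 2 to compound 3 (0.36 log units; beyond the scatter) as its nearest and furthest gaps.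

Compound 4 `O=C1C=C[C@@H](OCc2ccccc2)[C@@H]([C@@H](CO)OCc2ccccc2)O1` follows from hydrogen in place of (2-(4-fluorophenyl)ethenyl)carbonyl on an oxygen on a saturated carbon as the structural change, which is hydrogen in place of (2-(4-fluorophenyl)ethenyl)carbonyl on an oxygen on a saturated carbon.

The measured steps bear on this only indirectly. Among the measured compounds shown here, they change a substituent on the aromatic ring, and the modest 2.5-fold lower number from compound 1 to compound 3 (0.40 log units; beyond the scatter) is joined by no step that removes the whole ester. The data therefore fix no direction, and in this assay no step beyond the scatter is expected as the central case. The expected change is a 1.2-fold higher number from compound 2 to compound 4 (0.09 log units; within the scatter) with wide uncertainty. Compound 4 is estimated at 15000 nM as a middle value. The estimated range for compound 4 runs from 4000 nM to 55000 nM in this read-out.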

Compound 4, half-maximal inhibitory concentration: 12900 nM
Estimate against measurement, compound 4: 1.2-fold (0.07 log units) above, and the stated range covers the measured number.
By their numbers in this assay, from the lowest: compound 3; then compounds 2, 4 and 1 (each within the scatter of the next).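

Taking the whole (2-(4-fluorophenyl)ethenyl)carbonyl off the oxygen on a saturated carbon gives a 1.1-fold higher number from compound 2 to compound 4 (0.03 log units; within the scatter) in this assay, and taking off (2-phenylethenyl)carbonyl gives a 1.0-fold lower number from compound 1 to compound 4 (0.01 log units; within the scatter), so for these two esters, the free hydroxy and the ester cannot be told apart, which the aromatic-ring steps could not show. Compound 3 goes against any reading of the ester as silent throughout: compound 3 gives 5240 nM, while compound 4 gives 12900 nM, so the nitro ester alone separates from the hydroxy. No supporting data accompany these numbers to explain either outcome.

Still open, as far as these compounds go, is how an amine, a methyl ether or an amide at this position would compare with the hydroxy. Also open, from the compounds shown here alone, is whether the nitro value of compound 3 holds with a saturated chain in place of the ethenyl link.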